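Thiophen-3-yl in place of methyl on the indole-free core

The source may report more compounds than this note shows. Statements on the series, on what has been measured and on what is new or still open speak of the compounds shown alone.

The three measured compounds share one core and differ only in the group on an aromatic carbon of it. Compound 1 `CN1CCCN(CCn2ccc3ccc(N)cc32)CC1` gives 0% in an assay on HEK293 cells for binding affinity to 5-hydroxytryptamine receptor 7 (Homo sapiens), read by radioligand binding, tested at 1 uM; a lower number here means less inhibition, a higher number more inhibition at the concentration tested (going by the name of the read-out). Compound 2 `CN1CCCN(CCn2ccc3ccc(O)cc32)CC1` gives 28%, and compound 3 `Cc1ccc2ccn(CCN3CCCN(C)CC3)c2c1` gives 62%. Compound 3 stands highest of the three, with compound 2 nearest and compound 1 furthest. The steps at this position were a number 28 percentage points higher from compound 1 to compound 2 (beyond the scatter), a number 62 percentage points higher from compound 1 to compound 3 (beyond the scatter) and a number 34 percentage points higher from compound 2 to compound 3 (beyond the scatter), so every change measured so far sits at the same place as the one now considered.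

Compound 4 `CN1CCCN(CCn2ccc3ccc(-c4ccsc4)cc32)CC1` carries thiophen-3-yl in place of methyl on an aromatic carbon. Within the data shown here, none of the measured steps exchanges one carbon group for another, so they fix the direction only loosely: they show that changes at this position have moved the number by large amounts, but an aromatic ring has not been tried. The estimated step is a number 3 percentage points higher from compound 3 to compound 4 (within the scatter), and compound 4 is expected to give 65%, between 35% and 90%.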

Compound 4, a percentage reported as inhibition, at one concentration (the size of the read-out at that concentration, not a potency): 68%
Estimate against measurement, compound 4: 3 percentage points below; measured number inside the range.
By their numbers in this assay, from the lowest: compound 1; then compound 2; then compounds 3 and 4 (each within the scatter of the next).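

In this assay thiophen-3-yl in place of methyl gave a number 6 percentage points higher from compound 3 to compound 4 (within the scatter) and so showed that this aromatic carbon can carry an aromatic ring of five heavy atoms, not only a single carbon, without a step beyond the scatter. Thiophen-3-yl in place of hydroxy gave a number 40 percentage points higher from compound 2 to compound 4 (beyond the scatter) and in place of amino gave a number 68 percentage points higher from compound 1 to compound 4 (beyond the scatter) so the gaps that separated methyl from those two groups also hold for this much larger group. No measurement shown accounts for any of these steps.

As far as these compounds go, whether phenyl, thiophen-2-yl or a saturated ring such as cyclohexyl would fit the same pattern stays open. With a single tested concentration, the compounds shown also leave open how compound 3 and compound 4 compare in potency.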